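The source may report more compounds than this note shows. Statements on the series, on what has been measured and on what is new or still open speak of the compounds shown alone.

So far three related compounds have been tested in a functional assay on MDA-MB-231 cells (Homo sapiens) for antiproliferative activity, read by MTT assay, with a stated time of 48 h (a lower number here means a stronger inhibitor, a higher number a weaker inhibitor), and their numbers spread widely. Compound 1 `Cc1c(Cc2ccccc2)c(=O)oc2cc(OCCOc3no[n+]([O-])c3S(=O)(=O)c3ccccc3)ccc12` gives 6 nM and so holds the middle place, the second highest of the three numbers. Compound 2 `COc1cc(OCCOc2no[n+]([O-])c2S(=O)(=O)c2ccccc2)ccc1C(=O)/C=C/c1ccccc1` gives 0.5 nM as the nearest neighbour, a lower number that lies beyond the scatter of repeated measurements. Compound 3 `COCCOc1no[n+]([O-])c1S(=O)(=O)c1ccccc1` is the smallest structure of the set and gives 1230 nM as the furthest value, a far higher number and so a much weaker inhibitor.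

The next compound is compound 4 `Cc1c(Cc2ccc(F)cc2)c(=O)oc2cc(OCCOc3no[n+]([O-])c3S(=O)(=O)c3ccccc3)ccc12` which has not yet been measured. It differs from compound 1 in one place, fluoro in place of hydrogen on an aromatic carbon and the change is fluoro in place of hydrogen on an aromatic carbon, turning benzyl to 4-fluorobenzyl. For the measured compounds named here, no measured pair here differs in one place only, so the data offer no direct guide to a step of this kind. Compound 1 at 6 nM is the only anchor, and this single swap is far smaller than the structural gaps among the three measured compounds. The expected move a 1.2-fold lower number from compound 1 to compound 4 (0.08 log units; within the scatter) is estimated to stay within the usual scatter, with no firm direction. For compound 4 the estimate is 5 nM with an expected range from 1.5 nM to 18 nM for repeated measurements.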

Compound 4, half-maximal inhibitory concentration: 0.8 nM
The estimate for compound 4 lay 6.3-fold (0.80 log units) above the measured number; the measured number lies below the stated range.
By their numbers in this assay, from the lowest: compounds 2 and 4 (each within the scatter of the next); then compound 1; then compound 3.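

Going from benzyl to 4-fluorobenzyl gives a 7.5-fold lower number from compound 1 to compound 4 (0.88 log units; beyond the scatter) in this assay, and this is the first direct reading of a single change in this set. It shows that this place on the benzyl ring, para to a large group, is not a silent part of the molecule in this assay: one heavy atom entering there moves the number beyond the scatter, even though the core of compound 1 stays the same. Nothing shown here explains why this swap has such an effect, so the step stands as an observation without a known cause.

A single step at a single position cannot tell whether the change belongs to fluoro in particular, or whether chloro, methyl or methoxy at the same place would move the number in the same way. It also leaves open whether fluoro would do the same elsewhere on this ring, and whether the step would hold up in a compound with a longer chain in place of the present link.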